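The compounds below may be only part of what the source reports. "The series", "measured", "known", "first", "only" and "open" are said of these compounds alone.

Compound 1 `FC(F)(F)c1ccc(CSc2nc(Nc3ccccc3Cl)c3ccccc3n2)cc1` is the stronger-looking of the two measured compounds, though only in the loose sense that its number is the lower one: in a functional assay on PC-3 cells (Homo sapiens) for cytotoxicity, read by MTT assay, with a stated time of 72 h (on this read-out higher numbers stand for weaker inhibition and lower numbers for stronger inhibition), compound 1 gives 20400 nM. Among the measured compounds shown here, its single neighbour in the data is compound 2 `Cc1ccccc1Nc1nc(SCc2ccc(C(F)(F)F)cc2)nc2ccccc12`, which in this assay gives 36900 nM. The change a 1.8-fold higher number from compound 1 to compound 2 (0.26 log units; within the scatter) swaps a methyl for a chloro on an aromatic carbon and stays inside the scatter, so the two compounds cannot be ranked against each other.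

Compound 3 `CCOc1ccc(Nc2nc(SCc3ccc(C(F)(F)F)cc3)nc3ccccc23)cc1` departs from compound 1 by a different route: 4-ethoxyphenyl in place of 2-chlorophenyl on a nitrogen on an aromatic ring. For the measured compounds named here, the one measured step concerns the same phenyl ring but a different substituent, and it produced no shift beyond the scatter; nothing in the data tests a 4-ethoxyphenyl or a move of the substituent to another place on that ring. With so little to lean on, the expected step of a 1.2-fold higher number from compound 1 to compound 3 (0.09 log units; within the scatter) is one of no more than the scatter, in either direction. Compound 3 is therefore estimated at 25000 nM in this assay, with a range from 8000 nM to 80000 nM.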

Compound 3, half-maximal inhibitory concentration: 32100 nM
Compound 3: the middle estimate sits 1.3-fold (0.11 log units) below what was measured; the range from low to high includes it.
By their numbers in this assay, from the lowest: compounds 1, 3 and 2 (each within the scatter of the next).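

The wider change at this place, a 1.6-fold higher number from compound 1 to compound 3 (0.20 log units; within the scatter), and the change from the methyl-bearing ring, a 1.1-fold lower number from compound 2 to compound 3 (0.06 log units; within the scatter), both stay inside the scatter in this assay, so compound 3 cannot be ranked against either neighbour. The earlier step had swapped only one small substituent on the ring, whereas these steps replace 2-chlorophenyl and 2-methylphenyl with 4-ethoxyphenyl, which changes the substituent and where it sits and brings an oxygen and a hydrogen-bond acceptor, and still none of the three groups on the nitrogen separates from the others. There is no outside evidence bearing on why these three compounds read alike, and the data offer no explanation of their own.

What the compounds leave open is whether this place is tolerant in general or whether these three groups merely happen to read alike, since a plain phenyl, a ring carrying an amine or a carboxylic acid, and a chain longer than ethoxy are all absent from the set. From the compounds shown here alone, the trifluoromethyl group and the rest of the core are also shared by all three compounds, so their part in the numbers remains untested.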